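The source may report more compounds than this note shows. Statements on the series, on what has been measured and on what is new or still open speak of the compounds shown alone.

Working notes on a hydroxamic acid series tested in a functional assay on K562 cells (Homo sapiens) for antiproliferative activity, read by MTT assay, with a stated time of 72 h; a lower number here means a stronger inhibitor, a higher number a weaker inhibitor.

Compound 1 `CN1CCN(c2ccc(C(=O)/C=C/c3ccc(/C=C/C(=O)NO)cc3)cc2)CC1` carries the 4-methylpiperazin-1-yl group and, in this assay, compound 1 gives 900 nM. Compound 2 `CN1CCN(c2cccc(C(=O)/C=C/c3ccc(/C=C/C(=O)NO)nc3)c2)CC1` gives 360 nM in this assay, and compound 3 `CN1CCN(c2ccccc2C(=O)/C=C/c2cccc(/C=C/C(=O)NO)c2)CC1` gives 1290 nM. Of the three numbers, compound 1 holds the second highest; the gap to compound 3 stays within the scatter, so no order between compound 1 and compound 3 can be read, while the gap to compound 2 lies beyond the scatter, compound 2 showing the lower number. No pair among these three differs in only one place, so no single-change step has been measured.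

Compound 4 `O=C(/C=C/c1ccc(/C=C/C(=O)c2ccccc2)cc1)NO` is the untested analogue of compound 1. Its change: hydrogen in place of 4-methylpiperazin-1-yl on an aromatic carbon. Without a measured step of this kind, the expected step from compound 1 to compound 4 is modest, in the direction of a higher number, and estimated as a 1.7-fold higher number from compound 1 to compound 4 (0.22 log units; within the scatter). Compound 4 is thus expected to give about 1500 nM in this assay, within a range of 500 nM to 5000 nM.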

Compound 4, half-maximal inhibitory concentration in the K562 assay: 2280 nM
For compound 4 the middle estimate is 1.5-fold (0.18 log units) below the measured one; low and high end bracket the measured number.
By their numbers in the K562 assay, from the lowest: compound 2; then compounds 1, 3 and 4 (each within the scatter of the next, the first and the last beyond it).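

Among the compounds shown here, the only single-change step so far shows that, in the K562 assay, hydrogen in place of 4-methylpiperazin-1-yl on an aromatic carbon gives a 2.5-fold higher number from compound 1 to compound 4 (0.40 log units; beyond the scatter), so within this pair the lower number belongs to the compound carrying the group. In a physicochemical assay for solubility, at pH 7.4 (a lower number here means a less soluble compound, a higher number a more soluble compound), compound 1 gives 1000 nM and compound 4 gives 3000 nM. The same change therefore goes with a more soluble compound, and in this pair the 4-methylpiperazin-1-yl group brings no gain in solubility: the measured solubility of compound 1, 1000 nM, and of compound 4, 3000 nM, a 3.0-fold higher number (0.48 log units; beyond the scatter)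

Going by these compounds, whether these steps belong to the whole group or only to its amine stays open, and a morpholin-4-yl or a dimethylamino group at the same place would separate the two. Also open, on these data alone, is whether the same change gives similar steps on the cores of compound 2 and compound 3.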